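Small Chain Change, Little Expected Shift

This account rests on a few compounds, and the source may have more. Where it says the series, first, only, none or still open, it means among the compounds named here.

- Compound 1 `Brc1cccc(Br)c1N(CC1CC1)C1=NCCN1` measured at 10.9
- Compound 2 `CCCN(C1=NCCN1)c1c(Br)cccc1Br` measured at 11
- Compound 3 `CC(C)CCN(C1=NCCN1)c1c(Br)cccc1Br` measured at 10.9

In a physicochemical assay for acid dissociation, compound 3 gives 10.9 and stands level with compound 1 at 10.9 and within the scatter of compound 2 (at 11). The unmeasured compound 4 `C=CCCN(C1=NCCN1)c1c(Br)cccc1Br` alters only the end of the chain (in detail: vinyl in place of isopropyl on a saturated chain carbon, two bonds along the chain from a nitrogen on an aromatic ring) and the same difference can be read as isobutyl to allyl.

The measured step at that same place, isopropyl in place of methyl, is a number 0.10 log units lower from compound 2 to compound 3 (within the scatter) and offers the closest guide. The other two steps, a number 0.10 log units higher from compound 1 to compound 2 (within the scatter) and no change at the digits printed from compound 1 to compound 3 (within the scatter) also, come from changes to the same chain. All three stay within the scatter. Among the compounds with values here, no measured compound carries vinyl at this place, so that group remains untested. No step beyond the scatter is therefore expected in this assay for this change. The expected step is a number 0.10 log units lower from compound 3 to compound 4 (within the scatter) and would remain within the scatter. For compound 4 the estimated value is 10.8 (expected range 10.5 to 11.1).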

Compound 4, acid dissociation constant: 11.2
For compound 4 the middle estimate is 0.40 log units below the measured one; the measured number lies above the stated range.
By their numbers in this assay, from the lowest: compounds 1, 3, 2 and 4 (each within the scatter of the next).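

In this assay, placing vinyl in place of isopropyl on a saturated chain carbon, two bonds along the chain from a nitrogen on an aromatic ring, gives a number 0.30 log units higher from compound 3 to compound 4 (within the scatter), so a chain with a double bond outside aromatic rings, new to this set, stays inside the scatter. The other comparisons agree, with a number 0.20 log units higher from compound 2 to compound 4 (within the scatter) and a number 0.30 log units higher from compound 1 to compound 4 (within the scatter), which means that all four chains on the shared core read alike in this assay. Nothing measured here bears on why these values sit so close together.

Still open, on these data alone, is whether an amine or a carboxylic acid on this chain would move the number beyond the scatter. As far as these compounds go, a much longer chain or a phenyl group at this place is equally open.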